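The source may hold more compounds than are shown below. What is called first, only, known or untested is meant among the compounds shown, and "the series" means these compounds.

Compound 2, `Cc1cc(/C=C/C#N)cc(C)c1Oc1cc(Nc2ccc(C#N)cc2)c(N)cc1C(N)=O`, stands at the low end of the two numbers recorded so far in a physicochemical assay for lipophilicity, read by HPLC, measured as octanol-water partition, with a stated time of 24 h, at pH 7.4; on this read-out lower numbers stand for lower lipophilicity and higher numbers for higher lipophilicity: compound 2 gives 3.53, while the nearest measured compound, compound 1, `CCNC(=O)c1cc(N)c(Nc2ccc(C#N)cc2)cc1Oc1c(C)cc(/C=C/C#N)cc1C`, gives 3.63, a gap that lies within the scatter of this kind of measurement. Going by the values given here, the single measured step between the two is a number 0.10 log units lower from compound 1 to compound 2 (within the scatter), again within the scatter. Compound 3, `CNC(=O)c1cc(N)c(Nc2ccc(C#N)cc2)cc1Oc1c(C)cc(/C=C/C#N)cc1C`, has not yet been measured in this assay. It differs from compound 2 in one place: methyl in place of hydrogen on an amide-type nitrogen. The step from compound 1 to compound 2 is the one that bears on this change, since it concerns the same amide-type nitrogen, replacing an ethyl with a hydrogen, and it was small; compound 3 now carries a methyl at that nitrogen, a group of one carbon, between the two measured cases. Compound 3 is therefore expected to lie close to compound 2, with an expected step of a number 0.05 log units higher from compound 2 to compound 3 (within the scatter), not beyond the scatter. The estimate for compound 3 in this assay is 3.58, with a range from 3.35 to 3.85.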

Compound 3, partition coefficient: 2.65
Estimate against measurement, compound 3: 0.93 log units above; measured number outside the range, below it.
By their numbers in this assay, from the lowest: compound 3; then compounds 2 and 1 (each within the scatter of the next).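

In this assay, the amide-type nitrogen turns out not to be a place where any small group gives the same number: methyl in place of hydrogen gives a number 0.88 log units lower from compound 2 to compound 3 (beyond the scatter), and hydrogen in place of methyl on the saturated chain carbon bound to that nitrogen gives a number 0.98 log units lower from compound 1 to compound 3 (beyond the scatter). The earlier compounds shown here showed only a number 0.10 log units lower from compound 1 to compound 2 (within the scatter), and that small step did not carry over to the methyl group on the same nitrogen. Among these three compounds, the number therefore does not follow the carbon count of the group on this nitrogen, since compound 3, with its methylcarbamoyl group, stands apart, while compound 2 and compound 1, with hydrogen and ethyl, lie within the scatter of each other.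

Nothing in the information at hand accounts for why the methyl compound stands apart. The compounds shown leave open whether this low number is special to the methyl group, and a longer chain such as propyl, or a second methyl on the same nitrogen, would show whether any other group there gives a similar number in this assay.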